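A few compounds are considered here, and "the series" means these few. Any claim that something is new, unique, unknown or untested is made for them only; others in the source may bear on it.

Working notes on the series. Among the compounds with values here, only two compounds have numbers so far. In a functional assay on the whole organism for positive allosteric modulation, with Mus musculus as the target (on this read-out lower numbers stand for an effect already at smaller amounts and higher numbers for an effect only at larger amounts of compound), compound 1 (`CCC(=O)N(c1cccc(Br)c1)C1CCCC1N(C)C`) gives 0.1 mg/kg and compound 2 (`CCNC1CCCC1N(C(=O)CC)c1ccc(Cl)c(Cl)c1`) gives 0.2 mg/kg. These two numbers lie within the usual scatter of each other, so compound 2 stands level with compound 1 and no order can be read between them.

Compound 3 (`CCC(=O)N(c1ccc(Cl)c(Cl)c1)C1CCCC1N(C)Cc1ccccc1`) has not yet been measured. It carries benzyl(methyl)amino in place of ethylamino on a saturated ring carbon. Within the data shown here, no pair of measured compounds isolates a change at this place, so the data give no direct precedent for its size. The starting point is compound 2 at 0.2 mg/kg, and from there a moderate move towards higher numbers in this assay is expected, beyond the scatter, although a smaller move would not be surprising. The expected size is a 5.0-fold higher number from compound 2 to compound 3 (0.70 log units; beyond the scatter), an estimate with wide margins. For compound 3 the estimated value is 1 mg/kg, with an expected range from 0.2 mg/kg to 6 mg/kg.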

Compound 3, dose for half-maximal effect: 0.2 mg/kg
Compound 3: the middle estimate sits 5.0-fold (0.70 log units) above what was measured; low and high end bracket the measured number.
By their numbers in this assay, from the lowest: compounds 1, 2 and 3 (each within the scatter of the next).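

In this assay, within the data shown here, the exchange of ethylamino for benzyl(methyl)amino gives no change at the digits printed from compound 2 to compound 3 (within the scatter) and is the first reading at this place on a saturated ring carbon. The result shows that this position, next to the ring atom that bears a large group, can take a group of 9 heavy atoms in place of one of 3, including a six-membered aromatic ring of carbon only, while the number stays within the scatter and the hydrogen-bond donor count of the entering group is 0 against 1 for the group that leaves. Nothing at hand bears on why the read-out holds across this change.

The benzyl and the methyl enter together in this one step, so the compounds shown leave open what each contributes on its own. Also open, on these data alone, is how the read-out responds on this ring carbon to a primary amine, a carboxylic acid or a longer chain such as phenethylamino, and whether the same exchange behaves alike on the core of compound 1, which differs from compound 2 in more than one place.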